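From Methoxy to Trifluoromethoxy on an Inactive Series

The source may report more compounds than this note shows. Statements on the series, on what has been measured and on what is new or still open speak of the compounds shown alone.

Of the compounds shown here, three have so far been tested in an ADME assay on cells for inhibition of anoctamin-2 (Homo sapiens), read by fluorescence, with a stated time of 20 min; a higher number here means a weaker inhibitor, a lower number a stronger inhibitor. Compound 1 `COc1cccc(-c2nnc(COc3ccc(Cl)cc3C)o2)c1` returns only a limit of the assay, > 100000 nM, so no number places it on a scale. Compound 2 `COc1ccccc1/C=N/NC(=O)c1cc2cc(Cl)ccc2o1` likewise returns only a limit of the assay, > 100000 nM. Compound 3 `Cc1cc(Cl)ccc1OCC(=O)N/N=C/c1ccco1` is recorded as "not active" (no number reported), without any number at all. Among the compounds with values here, two of the three values therefore sit at the limit of > 100000 nM in this assay, at which 2 of the 3 values shown sit, and compound 1 stands among them: none of the measured compounds shows measurable inhibition. Within the data shown here, no two measured compounds differ in a single place, so no step has been measured.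

Compound 4 `Cc1cc(Cl)ccc1OCc1nnc(-c2cccc(OC(F)(F)F)c2)o1` differs from compound 1 in one place: trifluoromethyl in place of methyl on an oxygen on an aromatic ring. Among the measured compounds shown here, with no measured step to rest on, and with compound 1 itself at a limit of the assay, the step from compound 1 to compound 4 is expected to be a number no higher from compound 1 to compound 4 (the limit leaves the size open), nothing beyond the scatter, and most likely a limit again rather than a number. Compound 4 is accordingly estimated at 100000 nM, within a range from 30000 nM to 300000 nM.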

Compound 4, half-maximal inhibitory concentration: "not active" (no number reported)
Compound 4 has no reported number here; the estimate stays without a comparison.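

In this assay, within the data shown here, compound 4 has no reported number, so no step from compound 1 to compound 4 can be read. Compound 1 gives only a limit of the assay, > 100000 nM. The compounds shown leave open what change, if any, would bring measurable inhibition.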